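The source may hold more compounds than are shown below. What is called first, only, known or untested is meant among the compounds shown, and "the series" means these compounds.

Of the compounds shown here, three sharing one core have been measured. In a functional assay on CHO cells (Homo sapiens) for antiproliferative activity against CHO (Cricetulus griseus), read by sulforhodamine B assay, with a stated time of 48 h (on this read-out lower numbers stand for stronger inhibition and higher numbers for weaker inhibition), compound 1 `Cc1cccc(NS(=O)(=O)c2ccc(N3CCNC3=O)cc2)c1` gives 230 nM and compound 2 `Cc1cc(C)cc(NS(=O)(=O)c2ccc(N3CCNC3=O)cc2)c1` gives 210 nM while compound 3 `Cc1ccc(C)c(NS(=O)(=O)c2ccc(N3CCNC3=O)cc2)c1` gives 77 nM as the lowest number of the three.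

The unmeasured compound 4 `O=C1NCCN1c1ccc(S(=O)(=O)Nc2cccc(Cl)c2)cc1` carries 3-chlorophenyl in place of 2,5-dimethylphenyl on a sulfonamide nitrogen, and the count of that difference is 3-chlorophenyl in place of 2,5-dimethylphenyl on a sulfonamide nitrogen here. Within the data shown here, no compound with chlorine has been measured, so the evidence is indirect.

Two steps lead to compound 3. They are a 3.0-fold lower number from compound 1 to compound 3 (0.48 log units; beyond the scatter) and a 2.7-fold lower number from compound 2 to compound 3 (0.44 log units; beyond the scatter) and both are modest. By contrast, a 1.1-fold lower number from compound 1 to compound 2 (0.04 log units; within the scatter) stays within the scatter. Compound 1 and compound 2 both lack the 2,5-dimethylphenyl group, and so does compound 4, so a modest step to a higher number is expected in this assay rather than a gain. The estimated change is a 3.0-fold higher number from compound 3 to compound 4 (0.48 log units; beyond the scatter) in this case. For compound 4 the expected value is 230 nM with an estimated range from 90 nM to 600 nM overall.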

Compound 4, half-maximal inhibitory concentration: 96 nM
For compound 4 the middle estimate is 2.4-fold (0.38 log units) above the measured one; measured number inside the range.
By their numbers in this assay, from the lowest: compounds 3 and 4 (each within the scatter of the next); then compounds 2 and 1 (each within the scatter of the next).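

In this assay, the sulfonamide nitrogen can carry 3-chlorophenyl instead of 2,5-dimethylphenyl without a change beyond the scatter, with a 1.2-fold higher number from compound 3 to compound 4 (0.10 log units; within the scatter) as the step. Chloro in place of methyl on the aromatic carbon gives a 2.4-fold lower number from compound 1 to compound 4 (0.38 log units; beyond the scatter) and 3-chlorophenyl in place of 3,5-dimethylphenyl gives a 2.2-fold lower number from compound 2 to compound 4 (0.34 log units; beyond the scatter) so, among these four compounds, a low number does not depend on the 2,5-dimethylphenyl group. Nothing available here explains what chlorine does at this position.

The compounds shown leave open whether 2,5-dichlorophenyl would keep or lower the number, and whether fluoro or methoxy on the same ring would behave like chloro. They also leave open what a carboxylic acid or an amine on this ring would do.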